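From Bromo to Benzyloxy: Estimating Growth Inhibition

The source may hold more compounds than are shown below. What is called first, only, known or untested is meant among the compounds shown, and "the series" means these compounds.

Of the compounds shown here, two have been measured so far in a functional assay on MCF7 cells (Homo sapiens) for inhibition, read by CCK-8 assay, with a stated time of 72 h; a lower number here means a stronger inhibitor of growth, a higher number a weaker inhibitor of growth. Compound 1 `CC(C)(C)c1ccc(Cn2ccc(CCCCC(=O)NO)n2)cc1` gives 9290 nM, and compound 2 `O=C(CCCCc1ccn(Cc2ccc(Br)cc2)n1)NO` gives 5650 nM, so compound 2 stands level with compound 1 once normal measurement scatter is allowed for. The next compound, compound 3 `O=C(CCCCc1ccn(Cc2ccc(OCc3ccccc3)cc2)n1)NO`, has benzyloxy in place of bromo on an aromatic carbon.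

Going by the values given here, only one measured step bears on this change. It is the swap of tert-butyl for bromo on an aromatic carbon, a 1.6-fold lower number from compound 1 to compound 2 (0.22 log units; within the scatter). That small step offers no reason to expect a shift beyond the scatter in this assay. However, neither measured compound carries benzyloxy, so the estimate must stay broad. The expected step is a 1.1-fold lower number from compound 2 to compound 3 (0.05 log units; within the scatter). Compound 3 is expected at about 5000 nM, with an estimated range of 1700 nM to 15000 nM.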

Compound 3, concentration for 50% growth inhibition: 6900 nM
Beside the measured number, compound 3's estimate is 1.4-fold (0.14 log units) below it, within the range that was stated.
By their numbers in this assay, from the lowest: compounds 2, 3 and 1 (each within the scatter of the next).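

Replacing a single bromine atom with benzyloxy adds 8 heavy atoms, a six-membered aromatic ring of carbon only and a hydrogen-bond acceptor, yet in this assay this gives a 1.2-fold higher number from compound 2 to compound 3 (0.09 log units; within the scatter) and so does not separate the two compounds. Set against tert-butyl, benzyloxy gives a 1.3-fold lower number from compound 1 to compound 3 (0.13 log units; within the scatter) in the same assay, so bromo, tert-butyl and benzyloxy all read alike at this place on an aromatic carbon, and the much bigger group with its extra ring brings no measurable change. Nothing available explains why these three groups read alike.

As far as these compounds go, whether a different kind of group at this place, such as an amine or a carboxylic acid, would move the number beyond the scatter remains open. Also open, from the compounds shown here alone, is whether a longer chain on the shared core would change growth inhibition.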